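This account rests on a few compounds, and the source may have more. Where it says the series, first, only, none or still open, it means among the compounds named here.

In a functional assay on HL-60 cells (Homo sapiens) for inhibition, read by CCK-8 assay, with a stated time of 48 h (on this read-out higher numbers stand for weaker inhibition and lower numbers for stronger inhibition), compound 2 `O=C(NCCNS(=O)(=O)c1ccc(-c2ccccc2OCc2ccccc2)s1)Nc1cc(Cl)cc(Cl)c1` gives 11700 nM. Of the two numbers that are known, this is the highest, which on this read-out means the weaker inhibition. Its nearest neighbour is compound 3 `O=C(NCCNS(=O)(=O)c1ccc(-c2ccccc2Oc2ccc([N+](=O)[O-])c([N+](=O)[O-])c2)s1)Nc1cc(Cl)cc(Cl)c1`, which gives 2300 nM; the change is a 5.1-fold lower number from compound 2 to compound 3 (0.71 log units; beyond the scatter). Compound 1 `O=C(NCCNS(=O)(=O)c1ccc(-c2ccccc2O[C@H]2CC[C@H](O)CC2)s1)Nc1cc(Cl)cc(Cl)c1` gives > 20000 nM, a limit of the assay rather than a number (the limit of > 20000 nM in this assay, at which 1 of the 3 values shown sits).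

Compound 4 `O=C(NCCNS(=O)(=O)c1ccc(-c2ccccc2OCc2ccccc2)s1)Nc1cccc([N+](=O)[O-])c1` has not yet been measured. It differs from compound 2 in one place: 3-nitrophenyl in place of 3,5-dichlorophenyl on an amide-type nitrogen. Within the data shown here, every measured step so far, whether an at least 1.7-fold lower number from compound 1 to compound 2 (0.23 log units; that floor lies within the scatter), an at least 8.6-fold lower number from compound 1 to compound 3 (0.93 log units; beyond the scatter) or a 5.1-fold lower number from compound 2 to compound 3 (0.71 log units; beyond the scatter), changed the group on the oxygen on the aromatic ring, while the part attached to the amide-type nitrogen stayed the same. None of them therefore speaks directly to this change, and the expectation rests on compound 2 alone.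

Among the measured compounds shown here, with no measured step to guide it, the estimated step is a 1.0-fold higher number from compound 2 to compound 4 (0.01 log units; within the scatter), expected to stay within the scatter. Compound 4 is therefore estimated at 12000 nM, with a range from 4000 nM to 30000 nM.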

Compound 4, half-maximal inhibitory concentration: 2800 nM
Compound 4: the middle estimate sits 4.3-fold (0.63 log units) above what was measured, and the stated range ends above it.
By their numbers in this assay, from the lowest: compounds 3 and 4 (each within the scatter of the next); then compound 2. At a limit, above all of these: compound 1.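

Among these compounds, the part attached to the amide-type nitrogen turns out to matter for this activity, something the earlier compounds could not show, as each of them changed only the group on the oxygen. In this assay, replacing 3,5-dichlorophenyl with 3-nitrophenyl gives a 4.2-fold lower number from compound 2 to compound 4 (0.62 log units; beyond the scatter), so inhibition becomes stronger and the step is larger than the usual scatter. Nothing measured here explains why this swap strengthens inhibition.

From the compounds shown here alone, it remains open whether the gain comes from adding the nitro group or from losing the two chlorines, and a plain phenyl, or an amine or a carboxylic acid in place of the nitro group, would help separate these. Going by these compounds, it is also open whether the same swap would strengthen inhibition with 3,4-dinitrophenyl rather than benzyl on the oxygen.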